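The source may hold more compounds than are shown below. What is called first, only, known or untested is meant among the compounds shown, and "the series" means these compounds.

Four compounds share one core, and compound 1 `CCOC(=O)c1sc2nc(SC)nc(-c3cccc(OC)c3)c2c1N` and compound 2 `COc1cccc(-c2nc(SC)nc3sc(C(=O)NCCO)c(N)c23)c1` were examined in a functional assay on HEK293 cells for agonist activity at lutropin-choriogonadotropic hormone receptor (Homo sapiens), read by cAMP accumulation (a higher number here means that more compound is needed for the effect, a lower number that less compound is needed), yet for neither of them was a result reported: in this assay compound 1 gives "not determined" (no result reported), and in this assay compound 2 gives "not determined" (no result reported). Compound 3 `COc1cccc(-c2nc(SC)nc3sc(C(=O)OC(C)(C)C)c(N)c23)c1` is the only one of the three with a number: in this assay compound 3 gives 1100 nM. Going by the values given here, as the sole value, it stands alone, with no measured neighbour to set it against, so nothing can be said of how it ranks. Compound 4 `COc1cccc(-c2nc(SC)nc3sc(C(=O)N(C)C(C)(C)C)c(N)c23)c1` has not yet been measured. The difference between compound 3 and compound 4 is methyl(tert-butyl)amino in place of tert-butoxy on a carbonyl carbon; seen one bond further out, the same difference reads tert-butoxycarbonyl to methyl(tert-butyl)carbamoyl. Among the compounds with values here, no pair of measured compounds shows what such a change does here, so the size of the step can only be expected, not read from neighbours. The expected step is a 1.5-fold higher number from compound 3 to compound 4 (0.16 log units; within the scatter), a small shift toward more compound being needed, or none beyond the scatter. Compound 4 is expected to give 1600 nM in this assay, within a range from 500 nM to 5500 nM.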

Compound 4, half-maximal effective concentration: 800 nM
Beside the measured number, compound 4's estimate is 2.0-fold (0.30 log units) above it; measured number inside the range.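

In this assay, putting methyl(tert-butyl)amino in place of tert-butoxy on the carbonyl carbon gives a 1.4-fold lower number from compound 3 to compound 4 (0.14 log units; within the scatter), so the two compounds cannot be told apart. Going by these compounds alone, this is the first pair of numbers at this position, and it shows that here an oxygen-linked bulky group and a nitrogen-linked one give readings that the usual scatter of repeats would cover. Nothing shown explains this result.

Both groups carry a tert-butyl, so the pair says nothing about what a different kind of group on this carbonyl carbon would do. A free carboxylic acid, or an amide bearing a longer chain ending in an amine, might move the number beyond the scatter, or might leave it where it is.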